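The compounds below may be only part of what the source reports. "The series", "measured", "known", "first", "only" and "open" are said of these compounds alone.

Compound 1 `COc1ccc(C(c2ccc(OC)c(OC)c2)[C@H](C)[C@@H](C)CO)cc1OC` and compound 2 `COC[C@H](C)[C@@H](C)C(c1ccc(O)c(OC)c1)c1ccc(O)c(OC)c1` share the same core and are the two compounds with numbers in hand. In a functional assay on HL-60 cells (Homo sapiens) for cytotoxicity, read by WST assay, with a stated time of 48 h (a lower number here means a stronger inhibitor, a higher number a weaker inhibitor), compound 1 gives 47000 nM. In this assay compound 2 gives 68000 nM. Compound 1 has the lower of the two numbers, but its gap to compound 2 lies within the usual scatter, so the two cannot be told apart on these measurements. Compound 3 `COc1ccc(C(c2ccc(OC)c(OC)c2)[C@@H](C)[C@@H](C)CO)cc1OC` has not yet been tested. Its relation to compound 1 is this: the two compounds have the same atoms and bonds and differ only in configuration as drawn: 1 of 2 stereo elements differ; a stereocentre at a saturated chain carbon is drawn S in compound 1 and R in compound 3. For the measured compounds named here, no measured pair with the same kind of change is available, so there is nothing to calibrate the step against. With only that to go on, the step is expected to be a 1.1-fold higher number from compound 1 to compound 3 (0.03 log units; within the scatter), that is, no change beyond the scatter in either direction. Compound 3 is therefore estimated to give about 50000 nM in this assay, with a likely range from 15000 nM to 150000 nM.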

Compound 3, half-maximal inhibitory concentration: > 100000 nM
Compound 3: a limit, no number (the forecaster's own chance of this, stated with the estimate: 15%); at least 2.0-fold (0.30 log units) between middle value and limit.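

In this assay compound 3 gives > 100000 nM, which is a limit of the assay and not a number. As far as these compounds go, the step is an at least 2.1-fold higher number from compound 1 to compound 3 (0.32 log units; beyond the scatter), so the drawn configuration at this saturated chain carbon matters here, something the earlier pair could not show, while the true size of the step stays unknown: the limit of > 100000 nM in this assay, at which 1 of the 3 values shown sits. Nothing else separates these two compounds, so the step can be traced to this one stereocentre alone: the fact that compounds 1 and 3 differ only in the configuration as drawn

The compounds shown leave open what happens when the other stereocentre is changed on its own. They also leave open whether this configuration would matter as much in a compound carrying an amine or a carboxylic acid.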